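From 4-chlorophenyl to 3-chlorophenyl

This account rests on a few compounds, and the source may have more. Where it says the series, first, only, none or still open, it means among the compounds named here.

Among the measured compounds shown here, in a physicochemical assay for solubility, read by nephelometry, measured as kinetic solubility, at pH 2.0 (on this read-out higher numbers stand for higher solubility and lower numbers for lower solubility), compound 2 `Cn1c(-c2ccc(Cl)cc2)cnc1NC(=O)c1ncc[nH]1` gives 50 ug/mL as the only actual number so far. Compound 1 `COc1ccc(-c2cnc(NC(=O)c3ncc[nH]3)n2C)cc1` stands at > 100 ug/mL and that value is a limit of the assay. Compound 3 `Cn1c(-c2cccc(Cl)c2)cnc1NC(=O)c1ncc[nH]1` has the same atoms as compound 2, joined differently (3-chlorophenyl in place of 4-chlorophenyl on an aromatic carbon). The sole measured step, an at least 2.0-fold lower number from compound 1 to compound 2 (0.30 log units; that floor lies within the scatter) and so not shown to exceed the scatter, changes a different group and offers only weak guidance. No shift beyond the scatter is therefore expected in this assay for this move. The expected change is no change at the digits printed from compound 2 to compound 3 (within the scatter) at this stage. The estimate for compound 3 is 50 ug/mL (expected range 20 ug/mL to 100 ug/mL).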

Compound 3, solubility: 12.5 ug/mL
The estimate for compound 3 lay 4.0-fold (0.60 log units) above the measured number, outside the stated range (below it).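

In this assay, the same atoms joined differently give a 4.0-fold lower number from compound 2 to compound 3 (0.60 log units; beyond the scatter). On this aromatic carbon, then, 3-chlorophenyl and 4-chlorophenyl are not interchangeable, which the earlier step, a swap of methoxy for chloro, could not show. Nothing shown accounts for this step.

On these data alone, whether an amine or a carboxylic acid in place of the chlorine would raise or lower the number remains open. Compound 1 also offers no exact number for comparison, only a limit: the limit of > 100 ug/mL in this assay, at which 1 of the 3 values shown sits.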